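Sulfonamide in place of prolinamide on the shared core

The compounds below may be only part of what the source reports. "The series", "measured", "known", "first", "only" and "open" are said of these compounds alone.

Compound 3 `O=C(NC[C@@H]1CCCc2cc(S(=O)(=O)c3cccc(F)c3)ccc21)[C@H]1CCCN1` is measured in an assay on isolated protein for displacement of a labelled ligand from 5-hydroxytryptamine receptor 6 (Homo sapiens) (on this read-out lower numbers stand for stronger inhibition and higher numbers for weaker inhibition), at 0.631 nM. That is the highest of the three numbers in hand: compound 1 `NC[C@@H]1CCCc2cc(S(=O)(=O)c3cc[nH]c3)ccc21` gives 0.316 nM, and compound 2 `CNC[C@@H]1CCCc2cc(S(=O)(=O)c3cc[nH]c3)ccc21` gives 0.159 nM, so compound 3 is separated beyond the scatter only from compound 2, while its gap to compound 1 lies within it. Compound 4 `CN(C[C@@H]1CCCc2cc(S(=O)(=O)c3cccc(F)c3)ccc21)S(C)(=O)=O` differs from compound 3 in one place: methyl(methylsulfonyl)amino in place of ((pyrrolidin-2-yl)carbonyl)amino on a saturated chain carbon bound to a saturated ring carbon. The only measured step among these compounds, a 2.0-fold lower number from compound 1 to compound 2 (0.30 log units; within the scatter), concerns methyl in place of hydrogen on an amine nitrogen and does not touch an exchange of the pyrrolidinyl carbonyl amino group for a methyl methylsulfonyl amino group, so no measured step bears directly on the change leading to compound 4. Without such a precedent the estimate stays close to compound 3, with a wide range toward higher numbers. Compound 4 is expected to give 1.5 nM in this assay, between 0.3 nM and 8 nM. The expected step is a 2.4-fold higher number from compound 3 to compound 4 (0.38 log units; beyond the scatter), a higher number that may or may not exceed the scatter.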

Compound 4, inhibition constant: 0.398 nM
For compound 4 the middle estimate is 3.8-fold (0.58 log units) above the measured one; the range from low to high includes it.
By their numbers in this assay, from the lowest: compounds 2, 1, 4 and 3 (each within the scatter of the next, the first and the last beyond it).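

In this assay, methyl(methylsulfonyl)amino in place of ((pyrrolidin-2-yl)carbonyl)amino on a saturated chain carbon bound to a saturated ring carbon gives a 1.6-fold lower number from compound 3 to compound 4 (0.20 log units; within the scatter) and so leaves the number indistinguishable from that of compound 3. At this place, therefore, the five-membered non-aromatic ring, the defined stereocentre and the hydrogen-bond donors of the leaving group can all go without a change that stands clear of the scatter. Nothing measured here accounts for this result.

Going by these compounds, whether a carboxylic acid, a longer chain or a methylsulfonylamino group without its methyl would fare the same at this place remains open. Also open, on these data alone, is whether the same exchange would give a similar result with the 3-fluorophenyl sulfonyl group replaced by the sulfonyl group of compound 1.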